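Naphthyl in Place of Formylphenyl on a Shared Core

A few compounds are considered here, and "the series" means these few. Any claim that something is new, unique, unknown or untested is made for them only; others in the source may bear on it.

Measured compounds:
compound 1, `c1ccc(-c2cn3ccnc3c(-c3ccc4ncn(C5CCCCC5)c4c3)n2)cc1`, 16.5%
compound 2, `COc1ccc(-c2cn3ccnc3c(-c3ccc4ncn(C5CCCCC5)c4c3)n2)cc1`, 94.3%
compound 3, `O=Cc1ccc(-c2cn3ccnc3c(-c3ccc4ncn(C5CCCCC5)c4c3)n2)cc1`, 27.8%

Of the compounds shown here, three built on one shared core have been tested in a functional assay on SK-MEL-2 cells (Homo sapiens) for inhibition, read by sulforhodamine B assay, with a stated time of 48 h, tested at 10 uM; on this read-out higher numbers stand for more inhibition at the one concentration tested (going by the name of the read-out) and lower numbers for less inhibition. Compound 1 gives 16.5%, compound 2 gives 94.3%, and compound 3 gives 27.8%. Compound 3 stands second highest of the three: a number 11.3 percentage points higher from compound 1 to compound 3 (beyond the scatter), whereas a number 66.5 percentage points lower from compound 2 to compound 3 (beyond the scatter). The step to compound 4 `c1ccc2c(-c3cn4ccnc4c(-c4ccc5ncn(C6CCCCC6)c5c4)n3)cccc2c1` is naphthalen-1-yl in place of 4-formylphenyl on an aromatic carbon. Among the measured compounds shown here, no measured step exchanges the whole aryl group; each alters only one substituent on it, so they bear on this change only loosely. The step of a number 11.3 percentage points higher from compound 1 to compound 3 (beyond the scatter) shows that the formyl itself carries a modest gain, and the step of a number 77.8 percentage points higher from compound 1 to compound 2 (beyond the scatter) shows that a large gain came only with methoxy, which compound 4 lacks. Compound 4 is therefore expected to lose the formyl contribution without gaining elsewhere, giving an expected step of a number 2.8 percentage points lower from compound 3 to compound 4 (within the scatter), likely within or near the scatter. The estimate for compound 4 in this assay is 25%, with a range from 5% to 70%.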

Compound 4, a percentage reported as inhibition, at one concentration (the size of the read-out at that concentration, not a potency): 2.3%
Estimate against measurement, compound 4: 22.7 percentage points above; measured number below the stated range.
By their numbers in this assay, from the lowest: compound 4; then compound 1; then compound 3; then compound 2.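

In this assay, naphthalen-1-yl gives a lower number than each of the three phenyl-based groups on this aromatic carbon, with a number 14.2 percentage points lower from compound 1 to compound 4 (beyond the scatter), a number 25.5 percentage points lower from compound 3 to compound 4 (beyond the scatter) and a number 92 percentage points lower from compound 2 to compound 4 (beyond the scatter). Thus the position does not simply reward more aromatic carbon: the second six-membered aromatic ring brings no gain, and compound 4 is the only one to fall short of the plain phenyl of compound 1. No measurement shown here accounts for this drop.

Going by these compounds, it remains open whether the high number of compound 2 is particular to its 4-methoxyphenyl group or would also appear with an ethoxy, a hydroxyl or an amine in its place. Nor do these compounds show whether a methoxy on the naphthalen-1-yl group would recover the lost inhibition.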